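Swapping Dimethoxyphenyl for Chlorophenyl: Expected Antiproliferative Change

The source may report more compounds than this note shows. Statements on the series, on what has been measured and on what is new or still open speak of the compounds shown alone.

Compound 1 `COc1ccc(-c2nc(C)c(C(=O)CSc3nc(-c4ccc(OC)c(OC)c4)c(C#N)c(=O)[nH]3)s2)cc1` gives 57.6% in a functional assay on U-87MG ATCC cells for antiproliferative activity against U-87 MG (Homo sapiens), read by MTT assay, with a stated time of 48 h, tested at 10 uM (on this read-out lower numbers stand for a stronger effect and higher numbers for a weaker effect at the one concentration tested), the lowest of the three numbers, so it shows the strongest effect among them. Compound 2 `COc1ccc(-c2nc(SCC(=O)c3sc(-c4ccccc4)nc3C)[nH]c(=O)c2C#N)cc1OC` gives 69.8% and compound 3 `COc1ccc(-c2nc(SCC(=O)c3sc(-c4ccc(Cl)cc4)nc3C)[nH]c(=O)c2C#N)cc1OC` gives 83.3%; the steps between them are a number 12.2 percentage points higher from compound 1 to compound 2 (beyond the scatter), a number 25.7 percentage points higher from compound 1 to compound 3 (beyond the scatter) and a number 13.5 percentage points higher from compound 2 to compound 3 (beyond the scatter). Compound 4 `COc1ccc(-c2nc(C)c(C(=O)CSc3nc(-c4cccc(Cl)c4)c(C#N)c(=O)[nH]3)s2)cc1` differs from compound 1 by 3-chlorophenyl in place of 3,4-dimethoxyphenyl on an aromatic carbon. The measured steps concern a different part of the molecule, yet they all point one way: removing methoxy, and especially putting chloro in its place, raised the number. A rise beyond the scatter, of similar size, is therefore expected here too. Compound 4 is expected to give 76%, between 60% and 92%, meaning a number 18.4 percentage points higher from compound 1 to compound 4 (beyond the scatter).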

Compound 4, a percentage reported as activity, at one concentration (the size of the read-out at that concentration, not a potency): 90.6%
Estimate against measurement, compound 4: 14.6 percentage points below, and the stated range covers the measured number.
By their numbers in this assay, from the lowest: compound 1; then compound 2; then compounds 3 and 4 (each within the scatter of the next).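

The 3,4-dimethoxyphenyl on the core also matters: in this assay, 3-chlorophenyl in its place gives a number 33 percentage points higher from compound 1 to compound 4 (beyond the scatter) and counts as a large step, whereas the earlier modest steps all lay at the other end of the molecule. Moving away from methoxy therefore weakened the effect at both ends of compound 1. No measurement at hand gives a cause for this.

This single change removes two methoxy groups and adds chloro, so their separate contributions remain unresolved. Going by these compounds, how an amine or a carboxylic acid on this ring would read also stays open.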